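A few compounds are considered here, and "the series" means these few. Any claim that something is new, unique, unknown or untested is made for them only; others in the source may bear on it.

The study gathers a set of compounds on a shared core, and the read-out followed here is an ADME assay on L6 cells (Rattus norvegicus) for cytotoxicity, read by resazurin assay, with a stated time of 70 h; on this read-out higher numbers stand for weaker inhibition and lower numbers for stronger inhibition. Compound 3 `COc1cc(NC(C)CCCNC(=O)NNC(=O)/C(C)=C/c2ccccc2)c2ncccc2c1` is the one member for which a single number is shown: in this assay compound 3 gives 36500 nM. Compound 1 `COc1cc(NC(C)CCCNC(=O)/C=C/c2ccc(OC)c(OC)c2)c2ncccc2c1` returns only a limit of the assay in this assay, > 220000 nM. Compound 2 `COc1cc(NC(C)CCCNC(=O)NCCO)c2ncccc2c1` has no result in this assay at all, "not determined" (no result reported). The only cap visible among these entries is the limit of > 220000 nM in this assay, at which 1 of the 3 values shown sits, so compound 3 stands alone as the sole measured point.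

Against this thin background stands compound 4 `COc1cc(NC(C)CCCNC(=O)NNC(=O)/C=C/c2ccc(Cl)cc2)c2ncccc2c1`, not yet measured. Its difference from compound 3 is 2-(4-chlorophenyl)ethenyl in place of 1-methyl-2-phenylethenyl on a carbonyl carbon. For the measured compounds named here, no step between measured compounds is available to anchor a direction, and the change on the hydrazide carbonyl keeps the size of the group constant, so it is treated as neutral. In this assay the expected step is a 1.0-fold lower number from compound 3 to compound 4 (0.02 log units; within the scatter), not beyond the usual scatter. The estimate for compound 4 in this assay is therefore 35000 nM, with a range from 12000 nM to 110000 nM.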

Compound 4, half-maximal inhibitory concentration: 7300 nM
For compound 4 the middle estimate is 4.8-fold (0.68 log units) above the measured one, and the stated range ends above it.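

In this assay, the group on the hydrazide carbonyl carbon proves not to be a silent place: 2-(4-chlorophenyl)ethenyl in place of 1-methyl-2-phenylethenyl gives a 5.0-fold lower number from compound 3 to compound 4 (0.70 log units; beyond the scatter). For the compounds shown here, this is the first step in the set that can be read between two measured compounds, and it gives this position a direction on this read-out, towards stronger inhibition of the L6 cells. The two groups match in heavy-atom count and in hydrogen-bond donors and acceptors, so those counts do not separate them, and nothing measured here gives a reason for the step.

The single step joins two edits, the loss of the methyl of 1-methyl-2-phenylethenyl and the gain of the chlorine of 2-(4-chlorophenyl)ethenyl, and the compounds shown do not tell how much of the step belongs to each. They also leave open how this position would respond to a fluorine, a methoxy group or an amine on the phenyl ring in place of that chlorine, or to a longer chain between the carbonyl and the ring.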